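The source may hold more compounds than are shown below. What is called first, only, known or untested is meant among the compounds shown, and "the series" means these compounds.

Compound 1 `COc1ccc(C2=C(c3cc(OC)c(OC)c(OC)c3)C(=O)C(OC(C)=O)C2)cc1OC(C)C`: > 100 ug/mL
Compound 2 `COc1ccc(C2=C(c3cc(OC)c(OC)c(OC)c3)C(=O)C(OC(C)=O)C2)cc1`: "not determined" (no result reported)

In an ADME assay on HEK293 cells (Homo sapiens) for cytotoxicity, read by MTT assay, with a stated time of 72 h (a higher number here means a weaker inhibitor, a lower number a stronger inhibitor), compound 1 gives > 100 ug/mL, which is a limit and not a number. Compound 2 has no number of its own, its entry reading "not determined" (no result reported), so the only reference near it is the limit of > 100 ug/mL in this assay, at which 1 of the 2 values shown sits. Compound 3 `COc1ccc(C2=C(c3cc(OC)c(OC)c(OC)c3)C(=O)C(OC(C)=O)C2)cc1F` differs from it by fluoro in place of hydrogen on an aromatic carbon, ortho to a methoxy group. Within the data shown here, no measured step shows what this change does, so no step beyond the usual scatter is expected in this assay, and compound 3 is expected to lie close to the limit reached by compound 1. For compound 3 the estimated value is 90 ug/mL, with an expected range of 35 ug/mL to 130 ug/mL.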

Compound 3, half-maximal inhibitory concentration: 59 ug/mL
For compound 3 the middle estimate is 1.5-fold (0.18 log units) above the measured one, within the range that was stated.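

With fluoro ortho to a methoxy group, compound 3 gives the only figure in this assay among the compounds shown that is a number and not a limit. The change from isopropoxy to fluoro brings an at least 1.6-fold lower number from compound 1 to compound 3 (0.22 log units; that floor lies within the scatter) and so only a floor can be read, which does not establish a real change. That floor is set by a limit: the limit of > 100 ug/mL in this assay, at which 1 of the 3 values shown sits. From the compounds shown here alone, whether fluoro differs from the hydrogen of compound 2 stays open. So does how this assay would read an amine or a carboxylic acid at this position.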